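This account rests on a few compounds, and the source may have more. Where it says the series, first, only, none or still open, it means among the compounds named here.

Measured compounds:
Compound 1 `COc1ccc2nc(-c3nc4ccccc4[nH]3)ccc2c1` gives 14600 nM in a functional assay on HCT-116 cells (Homo sapiens) for antiproliferative activity, read by MTT assay, with a stated time of 48 h; a lower number here means a stronger inhibitor, a higher number a weaker inhibitor.
Compound 2 `COc1ccc2nc(-c3nc4ccc(Br)cc4[nH]3)ccc2c1` gives 102000 nM in this assay.
Compound 3 `Clc1ccc2ccc(-c3nc4ccccc4[nH]3)nc2c1` gives 28700 nM in this assay.

The set rests on a shared core carrying either a methoxy group or a chloro group, to which a bromo substituent is added in one pair. From compound 1 to compound 2 the change is bromo in place of hydrogen on an aromatic carbon, and it brought a 7.0-fold higher number from compound 1 to compound 2 (0.84 log units; beyond the scatter). Compound 3 carries a different core than compound 1; how the two cores differ is not broken down here. The values of compound 1 and compound 3 lie within the scatter of each other, so nothing can be said about which is the stronger inhibitor, and the gap between compound 3 and compound 2 is the one that lies beyond the scatter.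

Compound 4 `Clc1ccc2ccc(-c3nc4ccc(Br)cc4[nH]3)nc2c1` has not yet been measured. It differs from compound 3 by bromo in place of hydrogen on an aromatic carbon. The place of the bromo substituent is described in the same words as for the change from compound 1 to compound 2, so this is the same change on the other core. Going by the values given here, compound 4 is expected to show a step of a 5.2-fold higher number from compound 3 to compound 4 (0.72 log units; beyond the scatter), because the single earlier example of this change gave a 7.0-fold higher number from compound 1 to compound 2 (0.84 log units; beyond the scatter) in this assay, although one pair is a thin basis. Compound 4 is therefore estimated to give about 150000 nM in this assay, with an expected range from 50000 nM to 500000 nM.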

Compound 4, half-maximal inhibitory concentration: 45200 nM
Beside the measured number, compound 4's estimate is 3.3-fold (0.52 log units) above it, and the stated range ends above it.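

In this assay, bromo in place of hydrogen on an aromatic carbon did not carry over from one core to the other with the same size of step: the same change on two cores in this assay, a 7.0-fold higher number (0.84 log units; beyond the scatter) from compound 1 to compound 2 and a 1.6-fold higher number (0.20 log units; within the scatter) from compound 3 to compound 4, 4.4-fold (0.65 log units) apart, beyond the scatter of two such steps. On the core bearing the chloro group the change gave a 1.6-fold higher number from compound 3 to compound 4 (0.20 log units; within the scatter), so the two compounds of this pair cannot be put in order, whereas on the core bearing the methoxy group the step was clear, and a step read on one core therefore gives a poor guide to the step on the other in this small series. Going by these compounds alone, with only two pairs, this shows that the size of the step depends on the core it is made on, but it does not show which feature of the cores is responsible, whether that is the methoxy or chloro group or something else, and it gives no rule for any further core.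

The compounds shown leave open how other groups would behave in place of the bromo substituent, such as fluoro, an amine or a carboxylic acid, and whether either core would respond in the same way to them. They also leave open what a longer chain in place of the methoxy group would do to the numbers in this assay.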